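A few compounds are considered here, and "the series" means these few. Any claim that something is new, unique, unknown or untested is made for them only; others in the source may bear on it.

Working notes on the series, read in an ADME assay on the whole organism for cytotoxicity, with Artemia salina as the target, with a stated time of 24 h; on this read-out higher numbers stand for an effect only at larger amounts of compound and lower numbers for an effect already at smaller amounts. Compound 1 `CCc1cc(/C=C/C(=O)c2ccccc2NC(=O)NS(=O)(=O)c2ccc(C)cc2)cc(OC)c1OC` gives 19.2 ug/mL and compound 2 `CCOc1cc(/C=C/C(=O)c2ccccc2NC(=O)NS(=O)(=O)c2ccc(C)cc2)ccc1O` gives 19.2 ug/mL, with no change at the digits printed from compound 1 to compound 2 (within the scatter). Compound 3 `Cc1ccc(S(=O)(=O)NC(=O)Nc2ccccc2C(=O)/C=C/c2cccc([N+](=O)[O-])c2)cc1` gives 44.5 ug/mL, the highest of the three numbers.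

Compound 4 `Cc1ccc(S(=O)(=O)NC(=O)Nc2ccccc2C(=O)/C=C/c2ccc(Cl)cc2Cl)cc1` keeps the shared core and differs from compound 3 at one place, on a double-bonded chain carbon bound to a double-bonded chain carbon, with 2,4-dichlorophenyl in place of 3-nitrophenyl on a double-bonded chain carbon bound to a double-bonded chain carbon.

All three measured steps are exchanges at this same place. Two of them end at the 3-nitrophenyl group, a 2.3-fold higher number from compound 1 to compound 3 (0.37 log units; beyond the scatter) and a 2.3-fold higher number from compound 2 to compound 3 (0.37 log units; beyond the scatter), and both are modest. The third, the step between the first two compounds, shows no movement beyond the scatter. Among the measured compounds shown here, no measured compound carries a chlorine-bearing group at this place, so the direction rests on thin evidence. Compound 3 sits at the top of the range with 44.5 ug/mL, so a modest move to a lower number is the likelier outcome, of about the size of the two steps already seen. The expected step is a 2.0-fold lower number from compound 3 to compound 4 (0.31 log units; beyond the scatter). For compound 4 the estimated value is 22 ug/mL, with an expected range of 9 ug/mL to 55 ug/mL.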

Compound 4, concentration for half-maximal effect: 8.34 ug/mL
The estimate for compound 4 lay 2.6-fold (0.42 log units) above the measured number; the measured number lies below the stated range.
By their numbers in this assay, from the lowest: compound 4; then compounds 1 and 2 (each within the scatter of the next); then compound 3.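

At this place, on a double-bonded chain carbon bound to a double-bonded chain carbon, the exchanges had so far shown only that 3-nitrophenyl gives a higher number than the two oxygen-bearing groups, and 2,4-dichlorophenyl now shows that the number can also move well down in this assay. Compound 4 has the lowest number of the four, and the exchange from 3-nitrophenyl is the largest step in the series (a 5.3-fold lower number from compound 3 to compound 4 (0.73 log units; beyond the scatter)), clearly larger than the steps from the other two groups (a 2.3-fold lower number from compound 2 to compound 4 (0.36 log units; beyond the scatter); a 2.3-fold lower number from compound 1 to compound 4 (0.36 log units; beyond the scatter)), so the choice of group here sets the number in both directions, with the two oxygen-bearing groups in the middle of the range. No measurement in hand says why this group gives the lowest number.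

Among the compounds shown here, with only one chlorine-bearing group in the set, it remains open whether both chlorines are needed for the lower number, and how a plain phenyl, a fluorophenyl or an aminophenyl group would read at this place. As far as these compounds go, all four compounds also share the rest of the core, so whether this order of groups holds with a change elsewhere in the shared core remains open too.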